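Adding a Hydroxy Group on the Shared Core

A few compounds are considered here, and "the series" means these few. Any claim that something is new, unique, unknown or untested is made for them only; others in the source may bear on it.

Of the compounds shown here, two built on one shared core have been tested in a functional assay on MDA-MB-231 cells (Homo sapiens) for cytotoxicity, read by MTT assay; a lower number here means a stronger inhibitor, a higher number a weaker inhibitor. Compound 1 `COc1ccc(-c2cn(-c3ccc(OC)c(O)c3)nn2)cc1O` carries two hydroxy groups and two methoxy groups. In this assay compound 1 reaches only a limit of the assay, > 10000 nM, so no number is known for it. Compound 2 `COc1ccc(-c2cn(-c3ccc(OC)cc3)nn2)cc1` carries the two methoxy groups without any hydroxy. For compound 2 this assay also reports only a limit, > 100 nM, not a number. Among the compounds with values here, compound 2 thus stands at the limit of > 100 nM in this assay, at which 1 of the 2 values shown sits, and compound 1 at the limit of > 10000 nM in this assay, at which 1 of the 2 values shown sits; with two limits and no number, no step between measured compounds can be drawn, and the two values show only that each lies beyond its own limit.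

Compound 3 `COc1ccc(-n2cc(-c3ccc(OC)c(O)c3)nn2)cc1` differs from compound 2 in one place: hydroxy in place of hydrogen on an aromatic carbon. Within the data shown here, no measured pair shows what this change does in this assay. Since compound 1, which carries hydroxy groups, sits at the limit of > 10000 nM in this assay, at which 1 of the 2 values shown sits, compound 3 is expected to move toward weaker inhibition, the step that the limit leaves unreadable from compound 2 to compound 3 expected to exceed the scatter. Compound 3 is estimated at 5000 nM, within 500 nM to 50000 nM, and a limit rather than a number is quite possible.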

Compound 3, half-maximal inhibitory concentration: > 10000 nM
Compound 3: a limit, no number (the forecaster's own chance of this, stated with the estimate: 55%); middle value at least 2.0-fold (0.30 log units) away from the limit.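

In this assay compound 3 gives > 10000 nM, which is a limit and not a number. All three values are limits, so the steps linking compound 3 to compound 1 and compound 2 cannot be read. On these data alone, how far hydroxy in place of hydrogen on an aromatic carbon shifts inhibition in this assay remains open.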